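Series notes: furan-2-yl to pyridin-4-yl exchange

A few compounds are considered here, and "the series" means these few. Any claim that something is new, unique, unknown or untested is made for them only; others in the source may bear on it.

Measured in an assay on isolated protein for inhibition of DNA topoisomerase 1 (Homo sapiens), with a stated time of 30 min, tested at 100 uM; on this read-out higher numbers stand for a stronger effect at the one concentration tested and lower numbers for a weaker effect:
- compound 1, `Oc1ccc(-c2cc(-c3ccco3)nc(-c3ccccc3Cl)c2)cc1`: 3.9%
- compound 2, `Oc1ccc(-c2cc(-c3ccncc3)nc(-c3ccccc3Cl)c2)cc1`: 9.9%
- compound 3, `Oc1cccc(-c2cc(-c3ccco3)nc(-c3ccccc3Cl)c2)c1`: 0%

All three numbers are small and lie within the scatter of one another, so no order among them is claimed. The change from compound 1 to compound 2 is pyridin-4-yl in place of furan-2-yl on an aromatic carbon; it gave a number 6 percentage points higher from compound 1 to compound 2 (within the scatter). The two cores differ as 3-hydroxyphenyl in place of 4-hydroxyphenyl on an aromatic carbon, which gave a number 3.9 percentage points lower from compound 1 to compound 3 (within the scatter).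

Compound 4, `Oc1cccc(-c2cc(-c3ccncc3)nc(-c3ccccc3Cl)c2)c1`, is not yet measured. It arises from compound 3 by pyridin-4-yl in place of furan-2-yl on an aromatic carbon. This is the same kind of change as that from compound 1 to compound 2, not the same: in compound 3 the place is meta to a 3-hydroxyphenyl group, whereas in compound 1 it is meta to a 4-hydroxyphenyl group.

Beside the earlier step, the step from compound 3 to compound 4 in this assay is expected to be a number 5 percentage points higher from compound 3 to compound 4 (within the scatter), resting on the flat outcome of compound 1 to compound 2 and on compound 3 giving 0%. Compound 4 is therefore estimated at 5%, with a range from 0% to 15%.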

Compound 4, a percentage reported as inhibition, at one concentration (the size of the read-out at that concentration, not a potency): 0%
Compound 4: the middle estimate sits 5 percentage points above what was measured; low and high end bracket the measured number.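

In this assay, pyridin-4-yl in place of furan-2-yl on the core carrying 3-hydroxyphenyl gives no change at the digits printed from compound 3 to compound 4 (within the scatter), and the change reads alike on both cores: the same change on two cores in this assay, a number 6 percentage points higher (within the scatter) from compound 1 to compound 2 and no change at the digits printed (within the scatter) from compound 3 to compound 4, 6 percentage points apart, within the scatter of two such steps. With pyridin-4-yl held in place, 3-hydroxyphenyl in place of 4-hydroxyphenyl gives a number 9.9 percentage points lower from compound 2 to compound 4 (within the scatter), and this change also reads alike on both cores: the same change on two cores in this assay, a number 3.9 percentage points lower (within the scatter) from compound 1 to compound 3 and a number 9.9 percentage points lower (within the scatter) from compound 2 to compound 4, 6 percentage points apart, within the scatter of two such steps. Within the data shown here, this agreement shows only that neither change rises out of the scatter on either core; with all four numbers small at the one concentration tested, it does not show that a real effect of either change carries from one core to the other.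

The compounds shown leave open whether any group at the place of furan-2-yl or pyridin-4-yl, such as an amine or a carboxylic acid, would give a number beyond the scatter of these four. They also leave open what a longer chain on the hydroxyphenyl ring, or a plain phenyl in place of the 2-chlorophenyl group, would give.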